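A few compounds are considered here, and "the series" means these few. Any claim that something is new, unique, unknown or untested is made for them only; others in the source may bear on it.

Measured so far in a functional assay on ECa-109 cells for inhibition, with ECa-109 cell line (Homo sapiens) as the target, read by sulforhodamine B assay; on this read-out higher numbers stand for weaker inhibition and lower numbers for stronger inhibition:
- compound 1 `O=C1C=C(NCc2ccccc2)C(=O)c2c1nc1n2[C@H]2OC[C@@H](O)[C@H]2OC1`: > 8000 nM
- compound 2 `O=C1C(Nc2ccccc2)=CC(=O)c2c1nc1n2[C@H]2OC[C@@H](O)[C@H]2OC1`: 3560 nM

The value of compound 1, > 8000 nM, is a limit of the assay and not a number.

Within the data shown here, compound 2 therefore holds the only true number, 3560 nM, and it can be ranked against no other measured value. Among the measured compounds shown here, no step between two measured compounds differing in one place is available, so the series offers no direct precedent for the size of the next change.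

Compound 3 `Cc1ccc(NC2=CC(=O)c3c(nc4n3[C@H]3OC[C@@H](O)[C@H]3OC4)C2=O)cc1C` keeps the core of compound 2 and changes the group on the amine nitrogen: 3,4-dimethylphenyl in place of phenyl on an amine nitrogen. The expectation in this assay is a small move toward stronger inhibition, quite possibly no larger than the usual scatter. It is anchored only on compound 2 at 3560 nM. Expressed as a number, the expected change is a 1.4-fold lower number from compound 2 to compound 3 (0.15 log units; within the scatter). A result reported only as a limit remains possible. Compound 3 is estimated at 2500 nM, with an expected range of 900 nM to 7000 nM.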

Compound 3, half-maximal inhibitory concentration: 4090 nM
Beside the measured number, compound 3's estimate is 1.6-fold (0.21 log units) below it, within the range that was stated.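

In this assay, among these compounds, the first readable step concerns the group on the amine nitrogen, where 3,4-dimethylphenyl takes the place of phenyl: a 1.1-fold higher number from compound 2 to compound 3 (0.06 log units; within the scatter). Compound 2 and compound 3 thus lie within the scatter of each other, so this position accepts the two added methyl groups, 8 heavy atoms in place of 6, with no difference that this read-out can resolve. Compound 3 gives a number and not a limit, so the only limit in the series remains that of compound 1: the limit of > 8000 nM in this assay, at which 1 of the 3 values shown sits.

On these data alone, one step says little about the position as a whole, and it remains open whether a single methyl group on the phenyl reads the same as the pair. Also open, as far as these compounds go, is what a phenyl carrying a methoxy group or a carboxylic acid, or a saturated cyclohexyl group on the same nitrogen, would give in this assay.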